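A few compounds are considered here, and "the series" means these few. Any claim that something is new, unique, unknown or untested is made for them only; others in the source may bear on it.

Compound 3, `CNC(=O)N1CCCc2ccc(NC(=O)c3ccc(-c4ccn(S(C)(=O)=O)n4)cc3)cc21`, sits lowest of the three measured compounds in a functional assay on MV4-11 cells (Homo sapiens) for antiproliferative activity, with a stated time of 6 days, tested at 1.56 uM (on this read-out higher numbers stand for a stronger effect at the one concentration tested and lower numbers for a weaker effect), where compound 3 gives 8.81%. Its nearest neighbour is compound 1, `CNC(=O)N1CCCc2ccc(NC(=O)c3ccc(-c4ccccc4)cc3)cc21`, for which this assay records 19.7%; the furthest is compound 2, `CNC(=O)N1CCCc2ccc(NC(=O)c3ccc(-c4ccn(C)n4)cc3)cc21`, which in this assay gives 72.2%. The step of a number 10.9 percentage points lower from compound 1 to compound 3 (beyond the scatter) is modest, while a number 63.4 percentage points lower from compound 2 to compound 3 (beyond the scatter) is large, and the step of a number 52.5 percentage points higher from compound 1 to compound 2 (beyond the scatter) shows how strongly the 1-methyl-1H-pyrazol-3-yl group lifted the read-out relative to phenyl.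

Compound 4, `CNC(=O)N1CCCc2ccc(NC(=O)c3ccc(-c4cn[nH]c4)cc3)cc21`, differs from compound 3 in one place: 1H-pyrazol-4-yl in place of 1-(methylsulfonyl)-1H-pyrazol-3-yl on an aromatic carbon. The 1-(methylsulfonyl)-1H-pyrazol-3-yl group that leaves is the one tied to the lowest number in the set, and the two steps that bear on its departure, a number 63.4 percentage points lower from compound 2 to compound 3 (beyond the scatter) and a number 10.9 percentage points lower from compound 1 to compound 3 (beyond the scatter), were both downward. Removing that group is therefore expected to move compound 4 upward in this assay. Within the data shown here, the 1H-pyrazol-4-yl group that enters has no measured precedent here, so the size of the rise is uncertain; the methyl pyrazole in compound 2 suggests the upper end, the phenyl in compound 1 a more moderate one. On this basis compound 4 is expected to show a number 36.2 percentage points higher from compound 3 to compound 4 (beyond the scatter), landing at about 45%, within a range from 12% to 78%.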

Compound 4, a percentage reported as inhibition, at one concentration (the size of the read-out at that concentration, not a potency): 73.5%
Compound 4: the middle estimate sits 28.5 percentage points below what was measured; measured number inside the range.
By their numbers in this assay, from the lowest: compound 3; then compound 1; then compounds 2 and 4 (each within the scatter of the next).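

At this position, on an aromatic carbon para to a large group, this assay shows that a high read-out does not depend on the 1-methyl-1H-pyrazol-3-yl group alone: the step of a number 1.3 percentage points higher from compound 2 to compound 4 (within the scatter) leaves the two pyrazole-bearing compounds indistinguishable, although the point of attachment differs and the ring nitrogen carries no methyl. The step of a number 53.8 percentage points higher from compound 1 to compound 4 (beyond the scatter) gives phenyl a second pyrazole comparison of large size, so the low value of compound 1 now stands against two different pyrazoles, while compound 3 goes against any rule that a pyrazole alone is enough. The step of a number 64.7 percentage points higher from compound 3 to compound 4 (beyond the scatter) matches the earlier drop on methylsulfonyl in size, which singles out that substituent, rather than the five-membered aromatic ring it sits on, as the feature tied to the low read-out in these compounds.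

The compounds shown leave open whether attachment point and nitrogen substituent act separately, which a 1-methyl-1H-pyrazol-4-yl or an unsubstituted 1H-pyrazol-3-yl group would test, and whether a larger group on nitrogen such as ethyl or acetyl would be tolerated. No measurement at hand offers any explanation for these differences.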